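A few compounds are considered here, and "the series" means these few. Any claim that something is new, unique, unknown or untested is made for them only; others in the source may bear on it.

Compound 1 `CCOC(=O)C[C@H]1[C@@H](O[Si](C)(C)C(C)(C)C)[C@H](n2cnc3c(NC(=O)Nc4ccccc4)ncnc32)O[C@@H]1COC(=O)NC`: 5.7 nM
Compound 2 `CNC(=O)NC[C@H]1O[C@@H](n2cnc3c(NC(=O)Nc4ccccc4)ncnc32)[C@H](O[Si](C)(C)C(C)(C)C)[C@@H]1CC(=O)N(C)OC`: 7.79 nM

Among these two measurements in a functional assay on UO-31 cells (Homo sapiens) for antiproliferative activity (a lower number here means a stronger inhibitor of growth, a higher number a weaker inhibitor of growth), compound 2 has the higher number, yet the gap to compound 1 lies within the scatter, so the two read as alike. Compound 3 `CCOC(=O)C[C@H]1[C@@H](O[Si](C)(C)C(C)(C)C)[C@H](n2cnc3c(NC(=O)Nc4ccccc4)ncnc32)O[C@@H]1CNC(=O)NC` is not yet measured. It differs from compound 2 in one place (ethoxy in place of methoxy(methyl)amino on a carbonyl carbon); the carbonyl carbon carrying the change sits on a saturated chain carbon. Within the data shown here, with no measured step to lean on, and with compounds 1 and 2 alike, the change from compound 2 to compound 3 is expected to stay within the scatter a 1.2-fold lower number from compound 2 to compound 3 (0.08 log units; within the scatter). Compound 3 is estimated at 6.5 nM, between 3 nM and 14 nM.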

Compound 3, concentration for 50% growth inhibition: 12.1 nM
Compound 3: the middle estimate sits 1.9-fold (0.27 log units) below what was measured, and the stated range covers the measured number.
By their numbers in this assay, from the lowest: compounds 1, 2 and 3 (each within the scatter of the next, the first and the last beyond it).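

Putting ethoxy in place of methoxy(methyl)amino on the carbonyl carbon gives a 1.6-fold higher number from compound 2 to compound 3 (0.19 log units; within the scatter) in this assay, so this exchange on the carbonyl carbon leaves the read-out within the usual spread of repeat measurements. A different exchange, (methylcarbamoyl)amino in place of (methylcarbamoyl)oxy on the saturated chain carbon, gives a 2.1-fold higher number from compound 1 to compound 3 (0.33 log units; beyond the scatter) and so a modest loss of growth inhibition. Nothing available explains this loss. As far as these compounds go, what a carboxylic acid or an amine on that carbonyl carbon would do remains open. So does the effect of a longer chain in place of ethoxy.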